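The compounds below may be only part of what the source reports. "The series", "measured", "known", "first", "only" and "open" are said of these compounds alone.

Measured so far:
compound 1 `CSc1nc(NCCCNc2ccnc3cc(Cl)ccc23)c(C#N)c(-c2ccccc2)n1` — 4700 nM
compound 2 `CSc1nc(NCCCCNc2ccnc3cc(Cl)ccc23)c(C#N)c(-c2ccc([N+](=O)[O-])cc2)n1` — 960 nM

Compound 2 stands at the lower of the two numbers in an ADME assay on L1210 cells (Mus musculus) for inhibition, read by cell counting; a lower number here means a stronger inhibitor, a higher number a weaker inhibitor. Compound 1 gives 4700 nM in the same assay, a higher number, and the gap between the two lies beyond the usual scatter. The two compounds differ in more than one place, so no single-change step can be read from them.

Compound 3 `COc1cc(-c2nc(SC)nc(NCCCCNc3ccnc4cc(Cl)ccc34)c2C#N)cc(OC)c1OC` has not been measured. It is derived from compound 2 by the change (3,4,5-trimethoxyphenyl in place of 4-nitrophenyl on an aromatic carbon), that is, 3,4,5-trimethoxyphenyl in place of 4-nitrophenyl on an aromatic carbon. For the measured compounds named here, no measured pair differs in one place, so there is no step to lean on. The step from compound 2 to compound 3 is expected to be modest, leaning toward a somewhat higher number, as a 1.6-fold higher number from compound 2 to compound 3 (0.19 log units; within the scatter). Compound 3 is estimated at 1500 nM, with a range from 300 nM to 7000 nM.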

Compound 3, half-maximal inhibitory concentration: 3800 nM
For compound 3 the middle estimate is 2.5-fold (0.40 log units) below the measured one, and the stated range covers the measured number.
By their numbers in this assay, from the lowest: compound 2; then compounds 3 and 1 (each within the scatter of the next).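

In this assay, for the compounds shown here, 3,4,5-trimethoxyphenyl in place of 4-nitrophenyl gives a 4.0-fold higher number from compound 2 to compound 3 (0.60 log units; beyond the scatter), the only single-place step so far. The aryl group on this aromatic carbon, ortho to a cyano group, therefore changes the read-out when the rest of compound 2 is held fixed. Nothing available explains the direction or the size of this step.

As far as these compounds go, it remains open whether the step follows from losing 4-nitrophenyl or from gaining 3,4,5-trimethoxyphenyl; a 4-methoxyphenyl or 4-aminophenyl group at this position on the rest of compound 2 would help separate the two. From the compounds shown here alone, the contribution of the chain also remains open, since compound 1 differs from compound 2 in more than one place.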